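A few compounds are considered here, and "the series" means these few. Any claim that something is new, unique, unknown or untested is made for them only; others in the source may bear on it.

Three compounds of the series have been run in a functional assay on HL-60 cells (Homo sapiens) for antiproliferative activity, with a stated time of 24 h; on this read-out lower numbers stand for stronger inhibition and higher numbers for weaker inhibition. Compound 1 `NC(=O)c1c(NC(=O)c2ccccc2Cl)sc2c1CCN(Cc1cc(Cl)cc(Cl)c1)C2` gives 15800 nM in this assay. Compound 2 `NC(=O)c1c(NC(=O)c2ccccc2F)sc2c1CCN(Cc1cccc(Cl)c1)C2` gives 19800 nM in this assay, and compound 3 `NC(=O)c1c(NC(=O)c2cccc([N+](=O)[O-])c2)sc2c1CCN(Cc1c(Cl)cccc1Cl)C2` gives 18400 nM. Compound 1 has the lowest of the three numbers, but its gaps to compound 3 and to compound 2 both lie within the usual scatter, so no order among the three can be read from them. Among the compounds with values here, the three differ from one another in more than one place, so no single-change step is available; all three sit in the same weak band.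

Compound 4 `NC(=O)c1c(NC(=O)c2ccccc2Cl)sc2c1CCN(C(=O)Nc1c(Cl)cccc1Cl)C2` has not yet been measured. It differs from compound 1 in one place: (2,6-dichlorophenyl)carbamoyl in place of 3,5-dichlorobenzyl on an amine nitrogen in a ring. Within the data shown here, no measured pair shows what this exchange does on this read-out, so no direction can be supported from the data. For compound 4 the expected step is a 1.1-fold higher number from compound 1 to compound 4 (0.06 log units; within the scatter), nothing beyond the scatter. Compound 4 is accordingly estimated at 18000 nM in this assay, with a range from 7000 nM to 50000 nM, the range kept wide for lack of a comparable measured step.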

Compound 4, half-maximal inhibitory concentration: 17700 nM
Compound 4: middle estimate off by 1.0-fold (0.01 log units), on the high side, and the stated range covers the measured number.
By their numbers in this assay, from the lowest: compounds 1, 4, 3 and 2 (each within the scatter of the next).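

On the amine nitrogen in the ring, the exchange of 3,5-dichlorobenzyl for (2,6-dichlorophenyl)carbamoyl gives the series its first single-change step in this assay (a 1.1-fold higher number from compound 1 to compound 4 (0.05 log units; within the scatter)), and that step lies within the scatter. The entering group adds a carbonyl, with one hydrogen-bond donor and one hydrogen-bond acceptor, yet compound 4 stays in the same weak band as compound 1, so this position shows no sensitivity to this exchange on this read-out. No supporting measurement explains this flat result.

The exchange alters the link and the chlorine placement together, so a flat step could hide separate effects of the two that offset each other. From the compounds shown here alone, whether a sulfonyl link, a longer chain ending in an amine, or a carboxylic acid on this nitrogen would move the number out of this band remains open.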